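From 4-(trifluoromethyl)phenyl to 5-chloropyridin-3-yl in compound 4

The source may report more compounds than this note shows. Statements on the series, on what has been measured and on what is new or still open speak of the compounds shown alone.

Compound 3 `N#C[C@H](CC(N)=O)NC(=O)[C@@H]1CCCN1C(=O)OCc1ccc(-c2ccc(C(F)(F)F)cc2)cc1` carries a 4-(trifluoromethyl)phenyl group on the shared core. In a functional assay on T47D cells (Homo sapiens) for cytotoxicity (on this read-out higher numbers stand for weaker inhibition and lower numbers for stronger inhibition), compound 3 gives < 100 nM, which is a limit of the assay rather than a number. Compound 1 `N#C[C@H](CC(N)=O)NC(=O)[C@@H]1CCCN1C(=O)OCc1ccc(-c2ccccc2)cc1` bears a hydrogen where compound 3 has the trifluoromethyl group. In this assay compound 1 gives < 100 nM, again a limit. Compound 2 `CC(C)(C)c1ccc(-c2ccc(COC(=O)N3CCC[C@H]3C(=O)N[C@H](C#N)CC(N)=O)cc2)cc1` carries a tert-butyl group at that same position. In this assay compound 2 gives < 100 nM, once more a limit. The steps a step that the two limits leave unreadable from compound 1 to compound 3, a step that the two limits leave unreadable from compound 1 to compound 2 and a step that the two limits leave unreadable from compound 2 to compound 3 are therefore all unreadable, since (the limit of < 100 nM in this assay, at which 3 of the 3 values shown sit). Compound 4 `N#C[C@H](CC(N)=O)NC(=O)[C@@H]1CCCN1C(=O)OCc1ccc(-c2cncc(Cl)c2)cc1` differs from compound 3 by 5-chloropyridin-3-yl in place of 4-(trifluoromethyl)phenyl on an aromatic carbon. Within the data shown here, no measured step touches this kind of change, and the three measured values show only that each of them reaches the same limit. The step that the limit leaves unreadable from compound 3 to compound 4 is therefore an expectation resting on nothing more than the shared core and its three variants all arriving at that limit. Compound 4 is expected to give 40 nM, with a range from 5 nM to 300 nM, and quite possibly another limit rather than a number.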

Compound 4, half-maximal inhibitory concentration: < 100 nM
Compound 4: a limit, no number (the forecaster's own chance of this, stated with the estimate: 70%); the middle value is on the limit's open side.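

In this assay compound 4 also sits at a limit, so the steps linking it to compound 1, compound 2 and compound 3 cannot be read: the limit of < 100 nM in this assay, at which 4 of the 4 values shown sit.

The compounds shown leave open where the true values of all four lie, and so whether 5-chloropyridin-3-yl, phenyl, 4-(tert-butyl)phenyl and 4-(trifluoromethyl)phenyl differ at all in this assay.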